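The source may hold more compounds than are shown below. What is called first, only, known or untested is meant among the compounds shown, and "the series" means these compounds.

Working notes on the series.

Compound 1 `COc1ccc(OC)c(N2C(=O)CSC2c2cccc(C(=O)NCCCCc3ccccc3)c2)c1` is the reference point. In a functional assay on SJSA-1 cells (Homo sapiens) for inhibition, read by CCK-8 assay, with a stated time of 72 h, tested at 1 uM (on this read-out higher numbers stand for more inhibition at the one concentration tested (going by the name of the read-out) and lower numbers for less inhibition), compound 1 gives 48%, which is the lowest of the two numbers in hand. Within the data shown here, the only other measured member is compound 2 `COc1cc(F)ccc1N1C(=O)CSC1c1cccc(C(=O)NCCCCc2ccccc2)c1`, which in this assay gives 77%. Among the measured compounds shown here, the one measured step, a number 29 percentage points higher from compound 1 to compound 2 (beyond the scatter), replaces 2,5-dimethoxyphenyl with 4-fluoro-2-methoxyphenyl on an amide-type nitrogen in a ring.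

Compound 3 `COc1c(F)cccc1N1C(=O)CSC1c1cccc(C(=O)NCCCCc2ccccc2)c1` has not been measured in this assay. Its change from compound 1 is 3-fluoro-2-methoxyphenyl in place of 2,5-dimethoxyphenyl on an amide-type nitrogen in a ring. For the measured compounds named here, this is the same kind of exchange as in the measured step: 2,5-dimethoxyphenyl leaves, a fluoro-methoxyphenyl enters, and the one exchange on record, a number 29 percentage points higher from compound 1 to compound 2 (beyond the scatter), was upward and beyond the scatter. The fluorine sits in a different position in compound 3, so that step is a guide rather than a match, and an upward move of similar or somewhat smaller size is expected, a number 17 percentage points higher from compound 1 to compound 3 (beyond the scatter). For compound 3 the estimate in this assay is 65%, with a range from 45% to 85%.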

Compound 3, a percentage reported as inhibition, at one concentration (the size of the read-out at that concentration, not a potency): 1%
Compound 3: the middle estimate sits 64 percentage points above what was measured, and the stated range ends above it.
By their numbers in this assay, from the lowest: compound 3; then compound 1; then compound 2.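

In this assay, exchanging 2,5-dimethoxyphenyl for a fluoro-methoxyphenyl group on the amide-type nitrogen does not have one direction of effect: the earlier exchange went upward, whereas here there is a number 47 percentage points lower from compound 1 to compound 3 (beyond the scatter). The sharper comparison is a number 76 percentage points lower from compound 2 to compound 3 (beyond the scatter), where 4-fluoro-2-methoxyphenyl gives way to 3-fluoro-2-methoxyphenyl, so that the place of the fluorine on this aryl group alone separates the highest and lowest numbers among the three compounds. Nothing on hand accounts for this difference, which therefore stands as an observation without an explanation.

The compounds shown leave open whether the low number belongs to fluorine in particular or would also appear with another group in its place, such as the chlorine of 3-chloro-2-methoxyphenyl or the amine of 3-amino-2-methoxyphenyl. They also leave open how much the methoxy group contributes, since it is present in all three compounds, and whether a shorter or longer chain on the side amide would change the contrast between compound 2 and compound 3.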